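Allyl on the ring nitrogen of the dichloro analogue

The source may hold more compounds than are shown below. What is called first, only, known or untested is meant among the compounds shown, and "the series" means these compounds.

Measured compounds:
compound 1 `C=CCn1c(=O)/c(=C\c2cccc(Cl)c2)[nH]c(=O)/c1=C\c1ccccc1OC`: 4500 nM
compound 2 `COc1ccccc1/C=c1/[nH]c(=O)/c(=C\c2cccc(Cl)c2Cl)[nH]c1=O`: "not active" (no number reported)

In a functional assay on HL-60 cells (Homo sapiens) for cytotoxicity, read by CCK-8 assay, with a stated time of 72 h (on this read-out higher numbers stand for weaker inhibition and lower numbers for stronger inhibition), compound 1 gives 4500 nM. For compound 2 in this assay the result was reported as "not active" (no number reported), with no number given; it was recorded as inactive, so it stands below any point on the scale shown here. Compound 3 `C=CCn1c(=O)/c(=C\c2cccc(Cl)c2Cl)[nH]c(=O)/c1=C\c1ccccc1OC` carries allyl in place of hydrogen on an aromatic nitrogen. Among the compounds with values here, no measured pair shows this step, so its size and direction remain open; compound 1, which carries the same allyl group, gives 4500 nM. Compound 3 is expected to reach 9000 nM, within 2500 nM to 30000 nM, with a real chance that only a limit is reported.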

Compound 3, half-maximal inhibitory concentration: 2000 nM
Beside the measured number, compound 3's estimate is 4.5-fold (0.65 log units) above it, outside the stated range (below it).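

In this assay compound 2 is reported as "not active" (no number reported) and compound 3, with allyl in place of hydrogen on the aromatic nitrogen, gives a number (2000 nM), so measurable activity goes with allyl in this pair, although the size of that step cannot be read. With allyl held constant, chloro in place of hydrogen on an aromatic carbon gives a 2.3-fold lower number from compound 1 to compound 3 (0.35 log units; beyond the scatter) in the same assay. Nothing measured here explains either change.

Going by these compounds, whether a propyl chain, a longer chain or a carboxylic acid on that nitrogen would match allyl remains open. The chloro step is also known only with allyl present.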